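This account rests on a few compounds, and the source may have more. Where it says the series, first, only, none or still open, it means among the compounds named here.

Of the compounds shown here, two have been tested so far. In a functional assay on the whole organism with Mus musculus as the target (a lower number here means that less compound is needed, a higher number that more compound is needed for the effect), compound 1 `CNC(=O)/C=C(\C)c1cccc(C(F)(F)F)c1` gives 87.5 mg/kg. Compound 2 `O=C1CCC(O)(c2cccc(C(F)(F)F)c2)N1` is recorded only as a limit, > 200 mg/kg.

Compound 3 `CCN1C(=O)CCC1(O)c1cccc(C(F)(F)F)c1` follows from compound 2 by one change, ethyl in place of hydrogen on an amide-type nitrogen in a ring. Going by the values given here, no measured pair shows this change, so its size in this assay cannot be read from the data. Among the compounds with values here, the only number to set against it is that of compound 1, 87.5 mg/kg. A moderate move towards less compound needed is expected, although compound 3 may also remain at the limit of this assay. The expected step is an at least 1.5-fold lower number from compound 2 to compound 3 (0.18 log units; that floor lies within the scatter). For compound 3 the estimated value is 130 mg/kg, with an expected range of 60 mg/kg to 280 mg/kg.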

Compound 3, dose for half-maximal effect: > 100 mg/kg
Compound 3: only a limit was reported; the forecaster's own chance of this, stated with the estimate: 35%; the middle value does not contradict the limit.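

Going by these compounds alone, compound 2 and compound 3 are both recorded only as limits, and no step between them can be read. Left open is whether ethyl in place of hydrogen on an amide-type nitrogen in a ring changes the result in this assay at all, and in which direction.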